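Cytotoxicity notes on four related compounds

The source may report more compounds than this note shows. Statements on the series, on what has been measured and on what is new or still open speak of the compounds shown alone.

The series is followed in an ADME assay on WI-38 cells (Homo sapiens) for cytotoxicity, read by MTT assay, with a stated time of 72 h; a lower number here means a stronger inhibitor, a higher number a weaker inhibitor. Compound 1 `CN(C)CCn1cnnc1-c1cc(Oc2ccc(NC(=O)Nc3ccccc3C(F)(F)F)cc2F)ccn1` reaches only the limit of the assay, > 50000 nM. Compound 2 `CN(C)CCn1cnnc1-c1cc(Oc2ccc(NC(=O)Nc3ccc(F)c(F)c3)cc2F)ccn1` likewise gives only a limit, > 50000 nM. Going by the values given here, compound 3 `CN(C)CCCn1cnnc1-c1cc(Oc2ccc(NC(=O)Nc3ccccc3C(F)(F)F)cc2F)ccn1` is the one compound with a number, 28600 nM; from compound 1 to compound 3 the step is an at least 1.7-fold lower number from compound 1 to compound 3 (0.24 log units; that floor lies within the scatter), and this rests on ((dimethylamino)methyl in place of dimethylamino on a saturated chain carbon, two bonds along the chain from an aromatic nitrogen). The step from compound 1 to compound 2 is a step that the two limits leave unreadable from compound 1 to compound 2, which follows from the limit of > 50000 nM in this assay, at which 2 of the 3 values shown sit; the change behind it is 3,4-difluorophenyl in place of 2-(trifluoromethyl)phenyl on an amide-type nitrogen.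

Compound 4 `CN(C)CCCn1cnnc1-c1cc(Oc2ccc(NC(=O)Nc3ccc(F)c(F)c3)cc2F)ccn1` is not yet measured in this assay. It differs from compound 3 by 3,4-difluorophenyl in place of 2-(trifluoromethyl)phenyl on an amide-type nitrogen, the same change as that from compound 1 to compound 2, with the place described in the same words. The earlier step is unreadable because of the limit of > 50000 nM in this assay, at which 2 of the 3 values shown sit, so it gives no size to carry over. Of the two cores, compound 3 sits at a number and compound 1 at a limit, with the step between them within the scatter.

The expectation for compound 4 therefore rests on the value of compound 3, 28600 nM, and the step from compound 3 to compound 4 is estimated at a 1.2-fold higher number from compound 3 to compound 4 (0.09 log units; within the scatter). Compound 4 is expected to give about 35000 nM in this assay, within a range of 15000 nM to 60000 nM, with a fair chance that only a limit is reported.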

Compound 4, half-maximal inhibitory concentration: 15300 nM
Compound 4: the middle estimate sits 2.3-fold (0.36 log units) above what was measured, and the stated range covers the measured number.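

In this assay, (dimethylamino)methyl in place of dimethylamino on the chain gives an at least 3.2-fold lower number from compound 2 to compound 4 (0.51 log units; beyond the scatter), and set beside the same change on the other core, the comparison reads: the same change on two cores in this assay, an at least 1.7-fold lower number (0.24 log units; that floor lies within the scatter) from compound 1 to compound 3 and an at least 3.2-fold lower number (0.51 log units; beyond the scatter) from compound 2 to compound 4; the limit leaves it open whether they differ. The change thus gives a step beyond the scatter on the core of compound 2, while on the core of compound 1 its floor stays within the scatter, and neither step has a size that could be carried to another core, since each starts from a limit: the limit of > 50000 nM in this assay, at which 2 of the 4 values shown sit. The aryl change offers no firmer transfer: it gives a 1.9-fold lower number from compound 3 to compound 4 (0.27 log units; within the scatter), which supports no order between those two compounds, and its counterpart from compound 1 to compound 2 cannot be read.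

These compounds leave open whether a longer chain than that of compound 3 and compound 4 would continue the direction seen in this assay, and whether a cyclic amine such as morpholine in place of the dimethylamino group would behave in the same way. They also leave open how an unsubstituted phenyl or a nitrile-bearing phenyl would compare with the two aryl groups shown.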